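Notes on a methyl variant of compound 1

The compounds below may be only part of what the source reports. "The series", "measured", "known", "first", "only" and "open" are said of these compounds alone.

Among the measured compounds shown here, compound 1 `Nc1nc(-c2ccccc2)cn1/N=C/c1cc2ccccc2nc1Cl` is the only member of the series with a number in a functional assay on DLD-1 cells (Homo sapiens) for cytotoxicity, read by MTT assay, with a stated time of 48 h; on this read-out lower numbers stand for stronger inhibition and higher numbers for weaker inhibition: compound 1 gives 16400 nM. Compound 2 `Nc1nc(-c2ccc(Cl)cc2)cn1/N=C/c1cc2ccccc2nc1Cl` sits at a limit of this assay, > 50000 nM, with no number reached. For the measured compounds named here, the one measured step, an at least 3.0-fold higher number from compound 1 to compound 2 (0.48 log units; beyond the scatter), puts chloro in place of hydrogen on an aromatic carbon; it is known only as a bound because the limit of > 50000 nM in this assay, at which 1 of the 2 values shown sits, holds for compound 2.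

Compound 3 `Cc1ccc2nc(Cl)c(/C=N/n3cc(-c4ccccc4)nc3N)cc2c1` differs from compound 1 by methyl in place of hydrogen on an aromatic carbon. Going by the values given here, this change sits at a different place from the measured step, so that step does not bear on it directly, and no other step is available. No shift beyond the scatter is expected in this assay, in either direction. Close to compound 1, compound 3 is expected at 18000 nM, with a range of 7000 nM to 50000 nM. The estimated step is a 1.1-fold higher number from compound 1 to compound 3 (0.04 log units; within the scatter).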

Compound 3, half-maximal inhibitory concentration: 8790 nM
Compound 3: the middle estimate sits 2.0-fold (0.31 log units) above what was measured; measured number inside the range.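

In this assay, methyl in place of hydrogen on an aromatic carbon of the six-membered aromatic ring of carbon only gives a 1.9-fold lower number from compound 1 to compound 3 (0.27 log units; within the scatter). This position of the fused system therefore accepts methyl with the number staying within the scatter of compound 1, and the comparison rests on two actual numbers rather than a bound. Nothing shown gives a reason for this result.

On these data alone, whether an amine, a carboxylic acid or a longer chain on this same carbon would also stay within the scatter of compound 1 remains open, as does whether methyl on another aromatic carbon of the core would read alike. As far as these compounds go, compound 2 stands at a limit of the assay, > 50000 nM, and the full size of the chloro step also stays open.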